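This account rests on a few compounds, and the source may have more. Where it says the series, first, only, none or still open, it means among the compounds named here.

Compound 2 `Cc1nn(-c2nc(-c3ccc(Cl)c(Cl)c3)c(SC(C)C)s2)c(C(=O)O)c1-c1ccc(C(F)(F)F)cc1` carries a 4-(trifluoromethyl)phenyl group; in a functional assay on BJAB cells (Homo sapiens) for antiproliferative activity, with a stated time of 4 days (a lower number here means that less compound is needed, a higher number that more compound is needed for the effect), compound 2 gives 3500 nM. Its only neighbour, compound 1 `COc1ccc(-c2c(C)nn(-c3nc(-c4ccc(Cl)c(Cl)c4)c(SC(C)C)s3)c2C(=O)O)cc1`, bears methoxy in place of trifluoromethyl, and in this assay compound 1 gives 2100 nM; the step of a 1.7-fold higher number from compound 1 to compound 2 (0.22 log units; within the scatter) lies within the scatter, so compound 2 and compound 1 stand together on the numbers shown. Compound 3 `Cc1nn(-c2nc(-c3ccc(Cl)c(Cl)c3)c(SC(C)C)s2)c(C(=O)O)c1-c1cccc(Cl)c1` differs from compound 2 by 3-chlorophenyl in place of 4-(trifluoromethyl)phenyl on an aromatic carbon. Among the compounds with values here, the one step that bears on this change was small, so no step beyond the scatter is expected. Compound 3 is therefore estimated to give 3000 nM in this assay, with a range of 1200 nM to 7500 nM. The expected step is thus a 1.2-fold lower number from compound 2 to compound 3 (0.07 log units; within the scatter).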

Compound 3, half-maximal effective concentration: 13600 nM
For compound 3 the middle estimate is 4.5-fold (0.66 log units) below the measured one; measured number above the stated range.
By their numbers in this assay, from the lowest: compounds 1 and 2 (each within the scatter of the next); then compound 3.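

In this assay, this position on the five-membered aromatic ring responds to the choice of aryl group: 3-chlorophenyl in place of 4-(trifluoromethyl)phenyl gives a 3.9-fold higher number from compound 2 to compound 3 (0.59 log units; beyond the scatter), and 3-chlorophenyl in place of 4-methoxyphenyl gives a 6.5-fold higher number from compound 1 to compound 3 (0.81 log units; beyond the scatter). The earlier pair had stayed within the scatter, whereas both of these steps lie beyond it. No measurement available here accounts for this shift.

Going by these compounds, whether the chlorine itself or its place on the phenyl ring drives the change remains open. So does the outcome with an unsubstituted phenyl, or with a phenyl carrying an amine or a nitrile.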